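The compounds below may be only part of what the source reports. "The series", "measured", "known", "first", "only" and "open" are said of these compounds alone.

Compound 1 `C=CC(=O)Nc1cccc(Nc2ncnc(Nc3ccc(C(=O)N4CCCCC4)cc3)n2)c1` gives 6140 nM in a functional assay on Ramos cells (Homo sapiens) for antiproliferative activity, read by CCK-8 assay, with a stated time of 24 h; on this read-out higher numbers stand for weaker inhibition and lower numbers for stronger inhibition. Among the numbers reported this is the lower of the two, though compound 3 `C=CC(=O)Nc1cccc(Nc2nc(Cl)nc(Nc3ccc(Oc4ccccc4)cc3)n2)c1`, which gives 12300 nM in this assay, lies within the scatter of it, so the two cannot be told apart. For compound 2 `C=CC(=O)Nc1cccc(Nc2ncnc(Nc3ccc(-c4cccnc4)cc3)n2)c1` this assay reports no number but (the limit of > 100000 nM in this assay, at which 1 of the 3 values shown sits), recorded as > 100000 nM.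

Within the data shown here, the only measured step that bears on the present question is an at least 16-fold higher number from compound 1 to compound 2 (1.21 log units; beyond the scatter), a large loss on swapping the amide for the pyridyl ring.

Compound 4 `C=CC(=O)Nc1cccc(Nc2ncnc(Nc3ccc(-c4ccc(F)nc4)cc3)n2)c1` differs from compound 1 in 6-fluoropyridin-3-yl in place of (piperidin-1-yl)carbonyl on an aromatic carbon. Among the measured compounds shown here, this is the same exchange that separates compound 1 from compound 2, with a fluorine carried on the pyridine ring; the data hold no step that isolates the fluorine itself.

Compound 4 is therefore expected to track compound 2, with an expected step of a 13-fold higher number from compound 1 to compound 4 (1.11 log units; beyond the scatter) in this assay. Compound 4 is estimated at 80000 nM, within a range of 15000 nM to 300000 nM, and there is a fair chance that this assay again returns only a limit rather than a number.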

Compound 4, half-maximal inhibitory concentration: 59200 nM
Compound 4: the middle estimate sits 1.4-fold (0.13 log units) above what was measured, within the range that was stated.
By their numbers in this assay, from the lowest: compounds 1 and 3 (each within the scatter of the next); then compound 4. At a limit, above all of these: compound 2.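

Replacing (piperidin-1-yl)carbonyl with 6-fluoropyridin-3-yl, on an aromatic carbon para to a large group, gives in this assay a 9.6-fold higher number from compound 1 to compound 4 (0.98 log units; beyond the scatter), so a pyridine-bearing compound at this position can return a measured number, though one well short of the amide of compound 1. Compound 2 carries a limit and not a number: the limit of > 100000 nM in this assay, at which 1 of the 4 values shown sits.

The fluoro-for-hydrogen change on the pyridine ring gives an at least 1.6-fold lower number from compound 2 to compound 4 (0.22 log units; that floor lies within the scatter), so the data do not establish that the fluoro group makes any difference, although the true gap could be larger than that floor.

Whether the higher number of compound 4 relative to compound 1 follows from losing the carbonyl, losing the piperidine ring or gaining the pyridine ring remains open, as no compound shown separates these parts. Also open, going by these compounds, is how a morpholine amide or a 6-methoxypyridin-3-yl group at the same position would compare with compound 1 and compound 4.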